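The compounds below may be only part of what the source reports. "The series", "measured", "known", "first", "only" and "open" are said of these compounds alone.

Measured in an assay for inhibition of Polyunsaturated fatty acid 5-lipoxygenase (Homo sapiens), tested at 1 uM (a higher number here means a weaker effect of the compound at the concentration tested, a lower number a stronger effect), are three compounds: compound 1 `CCOC(=O)CSc1nc(Cl)cc(Nc2cccc(C)c2C)n1` with 76.9%, compound 2 `CCCCCCC(Sc1nc(Cl)cc(Nc2cccc(C)c2C)n1)C(=O)OCC` with 84.9%, and compound 3 `CCCCCCC(Sc1nc(Cl)cc(Oc2ccc3ncccc3c2)n1)C(=O)OCC` with 67.4%.

Compound 1 and compound 2 share one core and differ by hydrogen in place of hexyl on a saturated chain carbon bound to a carbonyl carbon and a sulfur. The step this change made is a number 8 percentage points lower from compound 2 to compound 1 (within the scatter). Compound 3 carries a different core; the difference between the two cores is not broken down here, and the values of compound 2 and compound 3 only show that compound 3 gave the lower number, beyond the scatter, while the gap between compound 1 and compound 3 lies within it.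

Compound 4 `CCOC(=O)CSc1nc(Cl)cc(Oc2ccc3ncccc3c2)n1` is not yet measured. It is obtained from compound 3 by hydrogen in place of hexyl on a saturated chain carbon bound to a carbonyl carbon and a sulfur, the same change as from compound 2 to compound 1, at the same place. The expected step is estimated at a number 6.4 percentage points lower from compound 3 to compound 4 (within the scatter), resting on the earlier step of a number 8 percentage points lower from compound 2 to compound 1 (within the scatter) being small and within the scatter, so that compound 4 is expected to land close to compound 3. The estimate for compound 4 is 61%, between 47% and 76%.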

Compound 4, a percentage reported as activity, at one concentration (the size of the read-out at that concentration, not a potency): "not active" (no number reported)
For compound 4 the study gives words and no number, and the estimate cannot be compared.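

For the compounds shown here, compound 4 is reported in this assay only in words, as not active, with no number, so no step from compound 3 to compound 4 can be read. Nothing shown here bears on this result. The compounds shown leave open what size of change hydrogen in place of hexyl brings on the core of compound 3.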